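Replacing an Ester Group on a Carbonyl Carbon

The source may hold more compounds than are shown below. What is called first, only, known or untested is meant among the compounds shown, and "the series" means these compounds.

Measured compounds:
- Compound 1 `CCn1c(C(=O)NCCN)ccc1C(CC)(CC)c1ccc(OCCC(O)(CC)CC)c(C)c1`: 1740 nM
- Compound 2 `C#CCCOC(=O)c1ccc(C(CC)(CC)c2ccc(OCCC(O)(CC)CC)c(C)c2)n1CC`: > 50000 nM (a limit, not a number)

Both readings come from a functional assay on Caco-2 cells (Homo sapiens) for antiproliferative activity, read by MTT assay, with a stated time of 48 h; on this read-out lower numbers stand for stronger inhibition and higher numbers for weaker inhibition. Compound 2 sits at the weak end of this pair, and its reading is only a limit (the limit of > 50000 nM in this assay, at which 1 of the 2 values shown sits). The next compound is compound 3 `CCOC(=O)C(CC(=O)OC)NC(=O)c1ccc(C(CC)(CC)c2ccc(OCCC(O)(CC)CC)c(C)c2)n1CC`, which differs from compound 2 on a carbonyl carbon: a group of 12 heavy atoms (7 carbon, 1 nitrogen, 4 oxygen; no ring) in place of a group of 5 heavy atoms (4 carbon, 1 oxygen; no ring), on a carbonyl carbon.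

Going by the values given here, one measured step bears on this change. In that step, (but-3-yn-1-yl)oxy took the place of (2-aminoethyl)amino on the same carbonyl carbon, giving an at least 28-fold higher number from compound 1 to compound 2 (1.45 log units; beyond the scatter), a large step beyond the scatter. The group at this carbon can therefore matter greatly in this assay. Compound 3 carries an amide there, as does compound 1 at 1740 nM, but the rest of its group is different, so only a partial recovery is expected. The expected change, towards lower numbers, is an at least 2.5-fold lower number from compound 2 to compound 3 (0.39 log units; beyond the scatter). Another limit reading remains possible. For compound 3 the estimated value is 20000 nM, with an expected range from 5000 nM to 60000 nM.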

Compound 3, half-maximal inhibitory concentration: 3020 nM
The estimate for compound 3 lay 6.6-fold (0.82 log units) above the measured number; the measured number lies below the stated range.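

In this assay, the group of 12 heavy atoms on the carbonyl carbon, which links through an amide nitrogen, replaces (but-3-yn-1-yl)oxy and gives an at least 16-fold lower number from compound 2 to compound 3 (1.21 log units; beyond the scatter). Going by these compounds alone, the (2-aminoethyl)amino group of compound 1 is thus not the only group at this carbon that gives a measurable reading, since the change on the amide-type nitrogen gives a 1.7-fold higher number from compound 1 to compound 3 (0.24 log units; within the scatter), a difference that stays within the scatter. Compound 2 reads only as a limit, so the true size of its step to compound 3 stays unknown: the limit of > 50000 nM in this assay, at which 1 of the 3 values shown sits.

From the compounds shown here alone, with a single ester here and two quite different amides, it remains open whether the amide link alone carries the difference or whether the rest of each group contributes. A plain methylamino group or a carboxylic acid on the same carbonyl carbon would help to separate these, and a small ester such as a methoxy group would show whether the weak reading of compound 2 extends beyond the but-3-yn-1-yl chain.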